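A few compounds are considered here, and "the series" means these few. Any claim that something is new, unique, unknown or untested is made for them only; others in the source may bear on it.

Series so far, read in a functional assay on HL-60 cells (Homo sapiens) for cytotoxicity, read by MTT assay; a higher number here means a weaker inhibitor, a lower number a stronger inhibitor
- compound 1 `COc1ccc(S(=O)(=O)NC(C2=CC(=O)c3c(O)ccc(O)c3C2=O)C(C)C)c(OC)c1` gives 400 nM
- compound 2 `CC(C)C(NS(=O)(=O)c1ccc(Br)cc1)C1=CC(=O)c2c(O)ccc(O)c2C1=O` gives "not determined" (no result reported)

Compound 2 has no number in this assay: its result was not determined, so it gives no starting value for the step that follows. Compound 3 `CC(=O)c1ccc(S(=O)(=O)NC(C2=CC(=O)c3c(O)ccc(O)c3C2=O)C(C)C)cc1` is the next entry, still unmeasured. The structural change is acetyl in place of bromo on an aromatic carbon, para to a large group, or 4-bromophenyl to 4-acetylphenyl. Among the measured compounds shown here, the data hold no measured step of this kind, and the size of this one cannot be read from them. For the measured compounds named here, no shift beyond the scatter is expected from the only number, that of compound 1 at 400 nM, and no direction is favoured. The estimated value for compound 3 is 500 nM, with an expected range of 150 nM to 1700 nM.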

Compound 3, half-maximal inhibitory concentration: 110 nM
Beside the measured number, compound 3's estimate is 4.5-fold (0.66 log units) above it, and the stated range ends above it.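

In this assay, among the compounds shown here, the aryl group on the sulfonyl sulfur clearly affects the read-out: 4-acetylphenyl in place of 2,4-dimethoxyphenyl gives a 3.6-fold lower number from compound 1 to compound 3 (0.56 log units; beyond the scatter), the first step and one beyond the scatter. The change from bromo to acetyl on the aromatic carbon para to a large group cannot be read, as compound 2 has no number to set against compound 3. No measurement shown here accounts for the step.

The step changes the aryl group as a whole, so the compounds shown do not separate the contribution of the entering acetyl from that of the departing methoxy groups. Going by these compounds, how an unsubstituted phenyl would read on the sulfonyl sulfur, or an amine or a carboxylic acid in place of the acetyl, remains open.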